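Moving the Chlorine on the Benzyl Arm of Compound 3

This account rests on a few compounds, and the source may have more. Where it says the series, first, only, none or still open, it means among the compounds named here.

Three related compounds have been tested so far: compound 1 `CC1=C(C(=O)Nc2ccc(Br)cc2)C(c2ccc(Cl)cc2Cl)N=C(SCc2ccc(Cl)cc2)N1`, compound 2 `COc1ccc(C2N=C(SCc3ccccc3)NC(C)=C2C(=O)Nc2ccc(Br)cc2)cc1` and compound 3 `COc1ccc(C2N=C(SCc3ccccc3Cl)NC(C)=C2C(=O)Nc2ccc(Br)cc2)cc1`. In a functional assay on the whole organism (artery, strain albino) with Rattus norvegicus as the target, with a stated time of 120 min, at a dose of 10 mg/kg by the oral route (a higher number here means more inhibition at the dose given (going by the name of the read-out), a lower number less inhibition), compound 1 gives 17.5%, compound 2 gives 8.2% and compound 3 gives 8.2%. Compound 3 stands level with compound 2, and its distance from compound 1 lies within the scatter, so nothing separates the three with confidence. Going by the values given here, the one measured step, no change at the digits printed from compound 2 to compound 3 (within the scatter), shows that adding the chlorine did nothing. Compound 4 `COc1ccc(C2N=C(SCc3ccc(Cl)cc3)NC(C)=C2C(=O)Nc2ccc(Br)cc2)cc1` differs from compound 3 by 4-chlorophenyl in place of 2-chlorophenyl on a saturated chain carbon bound to a sulfur. Among the compounds with values here, compound 1 also carries the 4-chlorobenzyl group but differs elsewhere, so only that single flat step bears on this change; an unchanged read-out is therefore expected, a number 1.8 percentage points higher from compound 3 to compound 4 (within the scatter). Compound 4 is estimated at 10%, between 0% and 22%.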

Compound 4, a percentage reported as inhibition, in the whole organism at one dose (the size of the read-out at that dose, not a potency): 16.5%
Compound 4: middle estimate off by 6.5 percentage points, on the low side; measured number inside the range.
By their numbers in this assay, from the lowest: compounds 2, 3, 4 and 1 (each within the scatter of the next).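

In this assay moving the chlorine on the benzyl arm gives a number 8.3 percentage points higher from compound 3 to compound 4 (within the scatter) and adding it to the unsubstituted benzyl gives a number 8.3 percentage points higher from compound 2 to compound 4 (within the scatter) so neither the place of this chlorine nor its presence can be told apart from the scatter. Putting 4-methoxyphenyl in place of 2,4-dichlorophenyl on the saturated ring carbon gives a number 1 percentage points lower from compound 1 to compound 4 (within the scatter) and this change cannot be told apart from the scatter either. No measurement at hand offers an explanation for these numbers. From the compounds shown here alone, whether an amine or a carboxylic acid on the benzyl ring would give a clearly different number remains open, as does a longer chain on the sulfur.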